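The source may hold more compounds than are shown below. What is called first, only, known or untested is meant among the compounds shown, and "the series" means these compounds.

The study examines four compounds in an ADME assay on PBMC cells (Homo sapiens) for cytotoxicity, with a stated time of 5 days; on this read-out lower numbers stand for stronger inhibition and higher numbers for weaker inhibition. Compound 1, `O=C(/C=C/c1ccc(N2CCCCC2)cc1)c1ccc(Br)s1`, carries a bromo group on a five-membered aromatic ring with one sulfur, and compound 2, `O=C(/C=C/c1ccc(N2CCCCC2)cc1)c1ccc(I)s1`, carries iodo in the same place; compound 3, `Brc1ccc(C2=NNC(c3ccc(N4CCCCC4)cc3)C2)s1`, and compound 4, `Ic1ccc(C2=NNC(c3ccc(N4CCCCC4)cc3)C2)s1`, repeat the bromo and iodo pairing on a second core. How the core of compound 1 differs from that of compound 3 is not broken down here.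

In this assay compound 1 reaches only the limit of the measurement, giving > 100000 nM. Compound 2 likewise gives no number but the limit > 100000 nM. For the measured compounds named here, compound 3 is the one compound with a read number, giving 80000 nM in this assay.

The change from compound 1 to compound 2 is iodo in place of bromo on an aromatic carbon, and in this assay it produces a step that the two limits leave unreadable from compound 1 to compound 2, a step that cannot be sized because the limit of > 100000 nM in this assay, at which 2 of the 3 values shown sit, holds both of its ends. The change from compound 3 to compound 4 is the same one, (iodo in place of bromo on an aromatic carbon), made on the other core.

For compound 4 the step is expected to be a 1.1-fold higher number from compound 3 to compound 4 (0.05 log units; within the scatter), which is about as much as can be said beside the unreadable earlier step. Going by the values given here, this expectation rests on compound 3 and its value 80000 nM, the one read number in this assay. Compound 4 is thus estimated to give 90000 nM, with a likely range from 45000 nM to 180000 nM, and a fair chance that only a limit is reported.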

Compound 4, half-maximal inhibitory concentration: > 100000 nM
Compound 4 was reported as a limit; the forecaster's own chance of this, stated with the estimate: 50%; at least 1.1-fold (0.04 log units) between middle value and limit.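

In this assay, from the compounds shown here alone, iodo in place of bromo on the core of compound 3 gives an at least 1.2-fold higher number from compound 3 to compound 4 (0.09 log units; that floor lies within the scatter); this is only a floor, and the true size of the step stays open, with compound 4 reported as a limit. For the compounds shown here, on the core of compound 1 the same change cannot be read, with both of its ends at a limit, so the two cores offer no pair of sizes to set side by side, and the data show neither that the change carries over from one core to the other nor that it behaves differently there. On neither core does the iodo compound give a read number, and a single read value has to anchor the whole comparison: the limit of > 100000 nM in this assay, at which 3 of the 4 values shown sit.

The compounds shown carry only bromo or iodo on the aromatic carbon next to the ring sulfur, so what chloro, a methyl group, a nitrile or an amine would give in that place stays open. Also open, going by these compounds, is whether any such group would bring compounds on both cores under the limit, so that one change could be sized on each.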